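The source may report more compounds than this note shows. Statements on the series, on what has been measured and on what is new or still open speak of the compounds shown alone.

Compound 2, `Nc1ccccc1NC(=O)c1ccc(CSC(=S)N2CCN(c3cccnc3)CC2)cc1`, carries a pyridin-3-yl group on an amine nitrogen in a ring. Within the data shown here, in a functional assay on HeLa cells (Homo sapiens) for antiproliferative activity, read by CCK-8 assay, with a stated time of 72 h, tested at 8 uM (a higher number here means a stronger effect of the compound at the concentration tested, a lower number a weaker effect), compound 2 gives 72.5%, the higher of the two numbers measured so far. Its nearest neighbour is compound 1, `Nc1ccccc1NC(=O)c1ccc(CSC(=S)N2CCN(Cc3ccccn3)CC2)cc1`, which differs only in bearing (pyridin-2-yl)methyl at the same place; in this assay compound 1 gives 61.4%. Among the measured compounds shown here, the one measured step, a number 11.1 percentage points higher from compound 1 to compound 2 (beyond the scatter), is beyond the usual scatter but still modest.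

Compound 3, `COc1ccc(N2CCN(C(=S)SCc3ccc(C(=O)Nc4ccccc4N)cc3)CC2)cc1`, has not yet been measured in this assay. Its difference from compound 2 is 4-methoxyphenyl in place of pyridin-3-yl on an amine nitrogen in a ring. For the measured compounds named here, no measured pair shows this particular exchange, so the only guide is that swapping the group at this ring nitrogen between compounds 1 and 2 moved the read-out by a modest amount. A change of similar or smaller size, in either direction, is therefore expected, and most likely one that stays within the scatter. The estimated step from compound 2 is a number 3.5 percentage points lower from compound 2 to compound 3 (within the scatter), and compound 3 is expected to give about 69%, within a range from 54% to 84%.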

Compound 3, a percentage reported as inhibition, at one concentration (the size of the read-out at that concentration, not a potency): 52.3%
Beside the measured number, compound 3's estimate is 16.7 percentage points above it; measured number below the stated range.
By their numbers in this assay, from the lowest: compounds 3 and 1 (each within the scatter of the next); then compound 2.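

This result shows that the group on the amine nitrogen of the six-membered ring matters more than the first step suggested: in this assay, exchanging pyridin-3-yl for 4-methoxyphenyl gives a number 20.2 percentage points lower from compound 2 to compound 3 (beyond the scatter), even though both groups are six-membered aromatic rings attached at the same place. An aromatic ring on this nitrogen is therefore not enough on its own to keep the higher read-out, since the exchange of (pyridin-2-yl)methyl for 4-methoxyphenyl gives a number 9.1 percentage points lower from compound 1 to compound 3 (within the scatter), which leaves compound 1 and compound 3 indistinguishable in this assay. No measurement here explains why the read-out falls from compound 2 to compound 3.

The step from compound 2 to compound 3 removes the ring nitrogen and adds the methoxy group at once, so the compounds shown cannot say which of the two changes accounts for it, and a plain phenyl group on this nitrogen would help to separate them. Going by these compounds, whether the ring nitrogen's place matters also stays open, a question that pyridin-4-yl or pyridin-2-yl attached directly to this nitrogen could address.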